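Cytotoxicity notes on three measured compounds and one pending

The compounds below may be only part of what the source reports. "The series", "measured", "known", "first", "only" and "open" are said of these compounds alone.

Three compounds have been measured in an ADME assay on HEK-293T cells (Homo sapiens) for cytotoxicity, read by MTT assay, with a stated time of 24 h; a lower number here means that less compound is tolerated, a higher number that more compound is tolerated:

compound 1 `Cc1ccc(-c2nn(-c3ccccc3)cc2-c2nc3ccccc3n2C(=O)c2cccc(C)c2)cc1` gives 195000 nM
compound 2 `Cc1cccc(C(=O)n2c(-c3cn(-c4ccccc4)nc3-c3ccc(F)cc3)nc3ccccc32)c1` gives 148000 nM
compound 3 `Cc1ccc(-c2nn(-c3ccccc3)cc2-c2nc3ccccc3n2C(=O)c2ccc(Cl)cc2)cc1` gives 216000 nM

Compound 1 and compound 2 differ only by fluoro in place of methyl on an aromatic carbon. In this assay this gives a 1.3-fold lower number from compound 1 to compound 2 (0.12 log units; within the scatter), so the two numbers cannot be told apart. Compound 1 and compound 3 differ by 4-chlorophenyl in place of 3-methylphenyl on a carbonyl carbon, and the step is a 1.1-fold higher number from compound 1 to compound 3 (0.04 log units; within the scatter), again within the scatter. For the measured compounds named here, all three measured values therefore sit in one band, with no compound standing apart from the others.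

Compound 4 `O=C(c1ccc(Cl)cc1)n1c(-c2cn(-c3ccccc3)nc2-c2ccc(F)cc2)nc2ccccc21` has not yet been measured. It differs from compound 3 by fluoro in place of methyl on an aromatic carbon. Going by the values given here, this is the same change as the one from compound 1 to compound 2, and the surroundings of the change are described in the same words in both pairs. The two cores on which the change is made differ by 4-chlorophenyl in place of 3-methylphenyl on a carbonyl carbon.

Since the same change made from compound 1 to compound 2 gave a 1.3-fold lower number from compound 1 to compound 2 (0.12 log units; within the scatter), the step from compound 3 to compound 4 is expected to be of similar size, a 1.3-fold lower number from compound 3 to compound 4 (0.12 log units; within the scatter), resting on that one earlier pair alone. Compound 4 is accordingly estimated at 165000 nM in this assay, with a likely range from 90000 nM to 300000 nM.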

Compound 4, half-maximal cytotoxic concentration: 179000 nM
For compound 4 the middle estimate is 1.1-fold (0.04 log units) below the measured one, within the range that was stated.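

In this assay, fluoro in place of methyl on an aromatic carbon gives a 1.2-fold lower number from compound 3 to compound 4 (0.08 log units; within the scatter), and this step agrees with the one seen on the other core: the same change on two cores in this assay, a 1.3-fold lower number (0.12 log units; within the scatter) from compound 1 to compound 2 and a 1.2-fold lower number (0.08 log units; within the scatter) from compound 3 to compound 4, 1.1-fold (0.04 log units) apart, within the scatter of two such steps. The second change, 4-chlorophenyl in place of 3-methylphenyl on a carbonyl carbon, gives a 1.2-fold higher number from compound 2 to compound 4 (0.08 log units; within the scatter) when read on the fluoro-bearing core, and it also agrees with its earlier counterpart: the same change on two cores in this assay, a 1.1-fold higher number (0.04 log units; within the scatter) from compound 1 to compound 3 and a 1.2-fold higher number (0.08 log units; within the scatter) from compound 2 to compound 4, 1.1-fold (0.04 log units) apart, within the scatter of two such steps. For the compounds shown here, the four compounds thus form a closed square in which neither change can be told from no change on either core, so the agreement shows only that the two changes combine without any visible departure, not that an effect of a definite size carries from one core to another, since every step is within the scatter and only two cores are involved in each comparison.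

From the compounds shown here alone, what remains open is whether any group on this aromatic carbon moves the number out of the shared band, for example an amine, a carboxylic acid or a longer chain in place of methyl or fluoro. Also open, going by these compounds, is whether a change that does produce a step beyond the scatter would carry across these cores in the same way.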